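The source may hold more compounds than are shown below. What is called first, only, known or untested is meant among the compounds shown, and "the series" means these compounds.

Working notes on the series. Going by the values given here, compound 3 `O=C(Nc1ccccc1O)C1CCc2ccccc2N1` gives 2680 nM in a functional assay on NUGC-3 cells (Homo sapiens) for cytotoxicity, read by sulforhodamine B assay, with a stated time of 72 h (a higher number here means a weaker inhibitor of growth, a lower number a stronger inhibitor of growth), the second highest of the three numbers measured so far; its nearest neighbour is compound 2 `O=C(Nc1ccccc1O)C1CCc2ccccc2N1C(=O)c1ccccc1` at 3780 nM, its furthest compound 1 `O=C(Nc1ccccc1C(F)(F)F)C1CCc2ccccc2N1C(=O)c1cccc(Cl)c1` at 754 nM. The step under consideration is (3-chlorophenyl)carbonyl in place of hydrogen on a nitrogen on an aromatic ring in a ring, giving compound 4 `O=C(Nc1ccccc1O)C1CCc2ccccc2N1C(=O)c1cccc(Cl)c1`. Among the compounds with values here, the only measured step on the same nitrogen is a 1.4-fold lower number from compound 2 to compound 3 (0.15 log units; within the scatter), which is within the scatter. Compound 1 carries the same 3-chlorophenylcarbonyl group but differs from compound 4 in a second place, so its value alone cannot be read as a step. The expectation is therefore no change beyond the scatter, a 1.1-fold lower number from compound 3 to compound 4 (0.03 log units; within the scatter), and compound 4 is estimated at 2500 nM with a range of 1000 nM to 6000 nM.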

Compound 4, concentration for 50% growth inhibition: 11000 nM
Compound 4: middle estimate off by 4.4-fold (0.64 log units), on the low side, outside the stated range (above it).
By their numbers in this assay, from the lowest: compound 1; then compounds 3 and 2 (each within the scatter of the next); then compound 4.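

In this assay, the acyl group on this nitrogen does matter: (3-chlorophenyl)carbonyl in place of hydrogen gives a 4.1-fold higher number from compound 3 to compound 4 (0.61 log units; beyond the scatter), while the step between benzoyl and hydrogen is a 1.4-fold lower number from compound 2 to compound 3 (0.15 log units; within the scatter). The single chloro in place of hydrogen on an aromatic carbon gives a 2.9-fold higher number from compound 2 to compound 4 (0.46 log units; beyond the scatter). With the (3-chlorophenyl)carbonyl group held constant, hydroxy in place of trifluoromethyl gives a 15-fold higher number from compound 1 to compound 4 (1.16 log units; beyond the scatter), the largest step listed so far.

Nothing available gives a reason for these steps. As far as these compounds go, whether a fluoro or a methoxy in place of the chloro, or an amine in place of the hydroxy, would shift the number in the same direction remains open.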